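Aryl for cyclohexyl on the amide carbonyl of compound 1

The source may hold more compounds than are shown below. What is called first, only, known or untested is meant among the compounds shown, and "the series" means these compounds.

Measured so far:
compound 1, `CC(C)OC(=O)C1=CN(C(=O)C2CCCCC2)CC(C)(C)c2cc(C#N)[nH]c21`: 6.5 nM
compound 2, `CC(C)OC(=O)C1CN(C(=O)c2ccc(F)cc2)CC(C)(C)c2cc(C#N)[nH]c21`: 640 nM

Two compounds of the series have numbers in an assay on HEK293 cells for agonist activity at Bile acid receptor (Homo sapiens), read by a luciferase reporter; a higher number here means that more compound is needed for the effect, a lower number that less compound is needed. Compound 1 gives 6.5 nM and stands lowest of the two. Compound 2 gives 640 nM, a higher number well beyond the scatter; compound 2 differs from compound 1 in more than one place, so the two values alone do not show which change carries the gap.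

Compound 3, `CC(C)OC(=O)C1=CN(C(=O)c2ccc(F)c(F)c2)CC(C)(C)c2cc(C#N)[nH]c21`, is not yet measured. It differs from compound 1 in one place: 3,4-difluorophenyl in place of cyclohexyl on a carbonyl carbon. Among the measured compounds shown here, no measured pair in the set isolates this change. For the measured compounds named here, compound 2, the only other compound, carries an aromatic ring on the same carbonyl and gives 640 nM, which points toward a higher number for compound 3, though without a clean comparison. The expectation for compound 3 in this assay is a step upward beyond the scatter, a 6.2-fold higher number from compound 1 to compound 3 (0.79 log units; beyond the scatter), yet well short of compound 2. The estimated value for compound 3 is 40 nM, with a range from 8 nM to 250 nM.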

Compound 3, half-maximal effective concentration: 6.3 nM
Estimate against measurement, compound 3: 6.3-fold (0.80 log units) above; the whole stated range lies above it.
By their numbers in this assay, from the lowest: compounds 3 and 1 (each within the scatter of the next); then compound 2.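

In this assay the exchange of cyclohexyl for 3,4-difluorophenyl on the carbonyl carbon gives a 1.0-fold lower number from compound 1 to compound 3 (0.01 log units; within the scatter) and so leaves the number within the scatter. This position therefore accepts an aromatic ring as well as a saturated one in the core of compound 1, and an aromatic ring on this carbonyl does not by itself bring a high number. Compound 2 differs from compound 3 in more than one place, so its value cannot be assigned to any one change, and no data here bear on why the two rings match.

Still open, on these data alone, is how an unsubstituted phenyl or a longer open chain on the same carbonyl carbon would read. As far as these compounds go, an amine or a carboxylic acid on the aromatic ring is equally open.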